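A few compounds are considered here, and "the series" means these few. Any claim that something is new, unique, unknown or untested is made for them only; others in the source may bear on it.

Notes on the series. Two pyrazole-containing ureas have been measured in a functional assay on HOP-62 cells (Homo sapiens) for inhibition, read by sulforhodamine B assay, with a stated time of 48 h; on this read-out higher numbers stand for weaker inhibition of growth and lower numbers for stronger inhibition of growth. Compound 1, `O=C(Nc1cccc(-n2cc(-c3ccncc3)c(-c3ccc(Cl)c(O)c3)n2)c1)Nc1cccc(C(F)(F)F)c1`, gives 6860 nM. Compound 2, `COc1cc(-c2nn(-c3cccc(NC(=O)Nc4ccc(Cl)c(Cl)c4)c3)cc2-c2ccncc2)ccc1Cl`, gives 1440 nM and thus stands at the lowest of the two numbers, with compound 1 as its nearest neighbour at a higher number, a gap beyond the scatter. Within the data shown here, compound 1 and compound 2 differ in two places at once, at the aryl ring on the core and at the aryl ring of the urea, so the two values together show only that the combined change matters and do not tell which part carries it.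

Compound 3, `O=C(Nc1cccc(-n2cc(-c3ccncc3)c(-c3ccc(Cl)c(O)c3)n2)c1)Nc1ccc(Cl)c(Cl)c1`, is not yet measured. It differs from compound 2 by hydrogen in place of methyl on an oxygen on an aromatic ring, and it shares the 4-chloro-3-hydroxyphenyl group with compound 1 while keeping the 3,4-dichlorophenyl urea of compound 2. Among the measured compounds shown here, with no single-point step known, the size of the step of a 2.1-fold higher number from compound 2 to compound 3 (0.32 log units; beyond the scatter) is estimated as a modest loss, within or near the scatter, with a weaker result more likely than a stronger one. Compound 3 is expected to give about 3000 nM, within a range of 1000 nM to 9000 nM.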

Compound 3, concentration for 50% growth inhibition: 2080 nM
Compound 3: middle estimate off by 1.4-fold (0.16 log units), on the high side; the range from low to high includes it.
By their numbers in this assay, from the lowest: compounds 2 and 3 (each within the scatter of the next); then compound 1.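

In this assay, hydrogen in place of methyl on the oxygen on the aromatic ring gives a 1.4-fold higher number from compound 2 to compound 3 (0.16 log units; within the scatter), so with the 3,4-dichlorophenyl urea in place, methoxy and hydroxy cannot be told apart at this position. With the 4-chloro-3-hydroxyphenyl group held constant, 3,4-dichlorophenyl in place of 3-(trifluoromethyl)phenyl on the amide-type nitrogen gives a 3.3-fold lower number from compound 1 to compound 3 (0.52 log units; beyond the scatter), a modest step beyond the scatter. Of the two places that changed together between compound 1 and compound 2, the aryl ring of the urea is therefore the one with a readable single-place step, while the oxygen substituent has none in this pair.

Still open, as far as these compounds go, is whether methoxy and hydroxy also remain indistinguishable with the 3-(trifluoromethyl)phenyl urea, and whether a longer chain on the same oxygen, such as ethoxy, or an amine or a carboxylic acid at this position would move the value beyond the scatter. No supporting measurement bears on these results.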